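Amine variation on the shared core: hexyl to vinyl

A few compounds are considered here, and "the series" means these few. Any claim that something is new, unique, unknown or untested is made for them only; others in the source may bear on it.

Measured so far:
compound 1 `CCCCCCCNc1nc(SC)nc2ncccc12` — 4070 nM
compound 2 `CSc1nc(NC2CC2)c2cccnc2n1` — 4900 nM

In a functional assay (Nicotiana tabacum) (a higher number here means a weaker inhibitor, a lower number a stronger inhibitor), compound 1 gives 4070 nM, and compound 2 gives 4900 nM; the two numbers lie within the scatter of each other, so neither is separated from the other. Compound 3 `C=CCNc1nc(SC)nc2ncccc12` has not been measured. It differs from compound 1 by vinyl in place of hexyl on a saturated chain carbon bound to a nitrogen on an aromatic ring. With only compound 2 as a comparison, a small amine substituent did not move the number, so the step of a 1.4-fold higher number from compound 1 to compound 3 (0.13 log units; within the scatter) is expected to stay within the scatter. For compound 3 the estimate is 5500 nM, with a range from 1800 nM to 17000 nM.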

Compound 3, half-maximal inhibitory concentration: 400 nM
The estimate for compound 3 lay 14-fold (1.14 log units) above the measured number; the whole stated range lies above it.
By their numbers in this assay, from the lowest: compound 3; then compounds 1 and 2 (each within the scatter of the next).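

In this assay the amine substituent turns out to matter: vinyl in place of hexyl on a saturated chain carbon bound to a nitrogen on an aromatic ring gives a 10-fold lower number from compound 1 to compound 3 (1.01 log units; beyond the scatter) for this change. Allyl in place of cyclopropyl on a nitrogen on an aromatic ring gives a 12-fold lower number from compound 2 to compound 3 (1.09 log units; beyond the scatter) on the same core, so the lower number goes with the double-bond substituent against both saturated ones. Nothing measured here accounts for the step.

Open, from the compounds shown here alone, is whether the step follows the double bond or the chain length. A propyl chain on the same nitrogen would separate the two.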